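The source may hold more compounds than are shown below. What is called first, only, known or untested is meant among the compounds shown, and "the series" means these compounds.

Compound 1 `CC(C)c1ccc(Nc2ccc3c(OCCCN4CCN(C)CC4)cccc3n2)cc1` gives 12300 nM in a functional assay on MDA-MB-468 cells (Homo sapiens) for inhibition, read by sulforhodamine B assay, with a stated time of 48 h; a lower number here means a stronger inhibitor of growth, a higher number a weaker inhibitor of growth.
Compound 2 `CN1CCN(CCCOc2cccc3nc(Nc4ccc(F)c(F)c4)ccc23)CC1` gives 2110 nM.
Compound 3 `CN1CCN(CCCOc2cccc3nc(Nc4cccc(Cl)c4)ccc23)CC1` is not yet measured.

Within the data shown here, compound 2 holds the lower of the two numbers so far, and compound 1 is its only neighbour, standing higher. Compound 3 differs from compound 2 by 3-chlorophenyl in place of 3,4-difluorophenyl on a nitrogen on an aromatic ring. Among the measured compounds shown here, the single step that bears on this change is a 5.8-fold lower number from compound 1 to compound 2 (0.77 log units; beyond the scatter), which exchanged one aryl group on the same nitrogen for another. Here one halogenated phenyl replaces another, so compound 3 is expected to stay near compound 2, with no step beyond the scatter, a 1.2-fold higher number from compound 2 to compound 3 (0.07 log units; within the scatter). Compound 3 is estimated at 2500 nM, between 1000 nM and 6500 nM.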

Compound 3, concentration for 50% growth inhibition: 1610 nM
Beside the measured number, compound 3's estimate is 1.6-fold (0.19 log units) above it; measured number inside the range.
By their numbers in this assay, from the lowest: compounds 3 and 2 (each within the scatter of the next); then compound 1.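

In this assay, exchanging one halogenated phenyl group for another on this nitrogen gives a 1.3-fold lower number from compound 2 to compound 3 (0.12 log units; within the scatter) and so does not separate 3,4-difluorophenyl from 3-chlorophenyl. Replacing 4-isopropylphenyl with 3-chlorophenyl gives a 7.6-fold lower number from compound 1 to compound 3 (0.88 log units; beyond the scatter) and so shows that the lower number is not confined to the 3,4-difluorophenyl group. Nothing available explains these numbers. From the compounds shown here alone, how an unsubstituted phenyl, 4-chlorophenyl or 3-methoxyphenyl group would compare on this nitrogen stays open. Going by these compounds, the rest of the molecule is the same in all three compounds, so the effect of a morpholine or a shorter chain elsewhere also stays open.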